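Reversing Part of a Sulfonamide Change on a Shared Core

A few compounds are considered here, and "the series" means these few. Any claim that something is new, unique, unknown or untested is made for them only; others in the source may bear on it.

Of the compounds shown here, two with a common core have been measured in a functional assay on MIA PaCa-2 cells (Homo sapiens) for inhibition, read by MTT assay, with a stated time of 3 days; a lower number here means a stronger inhibitor, a higher number a weaker inhibitor. Compound 1 `CCCN(CCC)S(=O)(=O)c1ccc(S(=O)(=O)N2CCC[C@@H](C(=O)OCC)C2)cc1` gives 600 nM in this assay. Compound 2 `CCOC(=O)[C@@H]1CCCN(S(=O)(=O)c2ccc(S(=O)(=O)N(C)C)cc2)C1` gives 300 nM in this assay, the lower of the two numbers, though the gap to compound 1 is small. Among the measured compounds shown here, the single step recorded so far, a 2.0-fold lower number from compound 1 to compound 2 (0.30 log units; within the scatter), is therefore not a real difference.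

Compound 3 `CCOC(=O)[C@@H]1CCCN(S(=O)(=O)c2ccc(S(=O)(=O)N(CC)C(C)C)cc2)C1` is the next compound. It differs from compound 2 by ethyl(isopropyl)amino in place of dimethylamino on a sulfonyl sulfur. This change partly undoes the change seen going from compound 1 to compound 2, so that step is the only one that bears on it, and it was within the scatter. No step beyond the scatter is therefore expected in this assay. For compound 3 the expected step is a 1.3-fold higher number from compound 2 to compound 3 (0.12 log units; within the scatter). Compound 3 is estimated at 400 nM in this assay, within a range from 150 nM to 1100 nM.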

Compound 3, half-maximal inhibitory concentration: 1200 nM
Estimate against measurement, compound 3: 3.0-fold (0.48 log units) below, outside the stated range (above it).
By their numbers in this assay, from the lowest: compounds 2, 1 and 3 (each within the scatter of the next, the first and the last beyond it).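

In this assay, among the compounds shown here, the group on this sulfonyl sulfur can matter: with ethyl(isopropyl)amino in place of dimethylamino, the result is a 4.0-fold higher number from compound 2 to compound 3 (0.60 log units; beyond the scatter) and gives the first step beyond the scatter. By contrast, ethyl(isopropyl)amino in place of dipropylamino gives a 2.0-fold higher number from compound 1 to compound 3 (0.30 log units; within the scatter) and so does not separate those two groups, just as dimethylamino and dipropylamino were not separated earlier. Nothing available here accounts for the step from dimethylamino to ethyl(isopropyl)amino.

Still open, as far as these compounds go, is whether a primary amine or a cyclic amine such as pyrrolidine or morpholine on the same sulfonyl sulfur would fall nearer to dimethylamino or to ethyl(isopropyl)amino. From the compounds shown here alone, it is also open whether this step would hold with a carboxylic acid in place of the ethyl ester on the shared core.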